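Ester Variation and Metabolic Stability in Mouse Liver Microsomes

A few compounds are considered here, and "the series" means these few. Any claim that something is new, unique, unknown or untested is made for them only; others in the source may bear on it.

In an ADME assay on microsomes from liver (Mus musculus) for metabolic stability, with a stated time of 30 min (on this read-out higher numbers stand for a more stable compound and lower numbers for a less stable compound), the measured compounds gave:
Compound 1 `CCCCOC(=O)Cc1c(C(C)C)nc(CCCC)n(Cc2ccc(-c3ccccc3-c3noc(=O)[nH]3)cc2)c1=O`: 21.6%
Compound 2 `CCCCc1nc(C(C)C)c(CC(=O)OCC(C)C)c(=O)n1Cc1ccc(-c2ccccc2-c2noc(=O)[nH]2)cc1`: 13.7%

Going by the values given here, compound 2 stands lowest of these two numbers, and its only neighbour is compound 1, the step of a number 7.9 percentage points lower from compound 1 to compound 2 (within the scatter) lying within the scatter. Compound 3 `CCCCc1nc(C(C)C)c(C(C)C(=O)OCC)c(=O)n1Cc1ccc(-c2ccccc2-c2noc(=O)[nH]2)cc1` carries a different change: 1-(ethoxycarbonyl)ethyl in place of (isobutoxycarbonyl)methyl on an aromatic carbon. Among the compounds with values here, the single measured step, a number 7.9 percentage points lower from compound 1 to compound 2 (within the scatter), swapped one ester alcohol chain for another and stayed within the scatter; no measured step covers a methyl added on the chain carbon itself. The step of a number 2.3 percentage points higher from compound 2 to compound 3 (within the scatter) is therefore expected to stay within the scatter. Compound 3 is estimated at 16%, in a range of 5% to 35%.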

Compound 3, percent of the compound remaining: 28%
Beside the measured number, compound 3's estimate is 12 percentage points below it; low and high end bracket the measured number.
By their numbers in this assay, from the lowest: compounds 2, 1 and 3 (each within the scatter of the next, the first and the last beyond it).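

At this aromatic carbon, 1-(ethoxycarbonyl)ethyl in place of (isobutoxycarbonyl)methyl gives a step beyond the scatter in this assay (a number 14.3 percentage points higher from compound 2 to compound 3 (beyond the scatter)), which the earlier pair did not show. In place of (butoxycarbonyl)methyl, the same group gives a step within the scatter (a number 6.4 percentage points higher from compound 1 to compound 3 (within the scatter)), so the difference holds against only one of the two esters. Nothing available gives a reason for either step.

This change alters the ester's alcohol chain and adds a methyl on the chain carbon together, and the compounds shown do not separate the two. On these data alone, how a carboxylic acid or an amide in place of the ester would read also stays open.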